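Swapping chloro for methoxy on a weakly cytotoxic compound

A few compounds are considered here, and "the series" means these few. Any claim that something is new, unique, unknown or untested is made for them only; others in the source may bear on it.

Compound 1 `COc1ccccc1/C=C1\CCC/C(=C\c2cccc(OC)c2OC)C1=O`: 12000 nM
Compound 2 `COc1ccc(/C=C2\CCC/C(=C\c3ccccc3Cl)C2=O)cc1OC`: 10400 nM

Both values come from a functional assay on MCF7 cells (Homo sapiens) for cytotoxicity, read by MTT assay, with a stated time of 72 h; a higher number here means a weaker inhibitor, a lower number a stronger inhibitor. Compound 2 gives 10400 nM and compound 1 gives 12000 nM. These two numbers lie within the scatter of each other, so neither compound can be ranked above the other.

The next compound is compound 3 `COc1ccccc1/C=C1\CCC/C(=C\c2ccc(OC)c(OC)c2)C1=O`, not yet measured. It differs from compound 2 in one place: methoxy in place of chloro on an aromatic carbon. In words, methoxy stands in place of chloro on an aromatic carbon, ortho to a large group, so 2-chlorophenyl becomes 2-methoxyphenyl.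

Among the compounds with values here, no measured pair shows this change on its own, so the evidence is indirect. Compound 1 also carries a 2-methoxyphenyl group and gives 12000 nM, close to the number for compound 2 at 10400 nM. No change beyond the scatter is therefore expected in this assay, and no direction can be favoured with confidence.

The expected change is a 1.0-fold lower number from compound 2 to compound 3 (0.02 log units; within the scatter).

For compound 3 the estimated value is 10000 nM, with an expected range from 4500 nM to 22000 nM.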

Compound 3, half-maximal inhibitory concentration: 8000 nM
Compound 3: the middle estimate sits 1.3-fold (0.10 log units) above what was measured, within the range that was stated.
By their numbers in this assay, from the lowest: compounds 3, 2 and 1 (each within the scatter of the next).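

In this assay the swap of 2-chlorophenyl for 2-methoxyphenyl can now be read on its own, and it gives a 1.3-fold lower number from compound 2 to compound 3 (0.11 log units; within the scatter) with the rest of the molecule unchanged. At this position, then, the two groups cannot be told apart in this cell assay, even though methoxy carries a hydrogen-bond acceptor and chloro carries none. Nothing in the data explains why the swap leaves the reading within the scatter, and no separate measurement of either group's properties is available to settle it.

From the compounds shown here alone, what remains open is whether this position responds to any group at all, since the two groups compared here give readings that cannot be separated, and a single pair says little about the position in general. An amine, a carboxylic acid or a longer chain such as butoxy in the same place would test this more sharply, and a hydrogen in place of the group would show whether anything needs to stand there at all.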